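The source may report more compounds than this note shows. Statements on the series, on what has been measured and on what is new or still open speak of the compounds shown alone.

Measured so far:
compound 1, `O=C(NS(=O)(=O)c1ccc(F)cc1)c1ccc(Nc2nc(NC3(c4ccc(Cl)cc4)CC3)nc(OCC(F)(F)F)n2)cc1`: 193 nm/s
compound 2, `CC(C)NCCS(=O)(=O)NC(=O)c1ccc(Nc2nc(NC3(c4ccc(Cl)cc4)CC3)nc(OCC(F)(F)F)n2)cc1`: 45 nm/s

In a physicochemical assay for permeability, using PAMPA, at pH 7.4 (on this read-out higher numbers stand for higher permeability and lower numbers for lower permeability), compound 2 has the lower of the two numbers shown, and its nearest neighbour is compound 1, which lies above it by a 4.3-fold lower number from compound 1 to compound 2 (0.63 log units; beyond the scatter). Compound 3, `CC(C)(C)NC(=O)NCCS(=O)(=O)NC(=O)c1ccc(Nc2nc(NC3(c4ccc(Cl)cc4)CC3)nc(OCC(F)(F)F)n2)cc1`, has not yet been measured. It differs from compound 2 by (tert-butyl)carbamoyl in place of isopropyl on an amine nitrogen. For the measured compounds named here, the only measured step is the one from compound 1 to compound 2, which exchanged the group on the sulfonyl sulfur; no measured pair exchanges the group on the amine nitrogen, so that step gives no direct guide to the direction here. The expectation for compound 3 therefore stays close to compound 2, with a wide range: the step from compound 2 to compound 3 is estimated at a 1.3-fold higher number from compound 2 to compound 3 (0.12 log units; within the scatter). Compound 3 is expected to give about 60 nm/s in this assay, within a range of 20 nm/s to 180 nm/s.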

Compound 3, apparent permeability: 49 nm/s
Estimate against measurement, compound 3: 1.2-fold (0.09 log units) above; low and high end bracket the measured number.
By their numbers in this assay, from the lowest: compounds 2 and 3 (each within the scatter of the next); then compound 1.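

In this assay, replacing isopropyl on the amine nitrogen with (tert-butyl)carbamoyl, which brings one hydrogen-bond donor and one hydrogen-bond acceptor, leaves the read-out within the scatter: a 1.1-fold higher number from compound 2 to compound 3 (0.04 log units; within the scatter). With this longer group in place, the chain on the sulfonyl sulfur still gives a number beyond the scatter of the 4-fluorophenyl compound, a 3.9-fold lower number from compound 1 to compound 3 (0.60 log units; beyond the scatter), so the gap to compound 1 now holds for two different groups on that nitrogen. No accompanying measurement bears on what lies behind this result.

For the compounds shown here, only one exchange on the amine nitrogen can be read so far, so it remains open whether a simple acetyl group or a carboxylic acid there would also leave the number in place. As far as these compounds go, whether a shorter or longer chain on the sulfonyl sulfur would narrow the gap to compound 1 also remains open.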